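Swapping an aryl for pyrimidinyl on a piperazine amide

This account rests on a few compounds, and the source may have more. Where it says the series, first, only, none or still open, it means among the compounds named here.

Measured so far:
- compound 1 `COc1ccc(N2CCN(C(=O)Cn3cnc([N+](=O)[O-])n3)CC2)cc1`: 133000 nM
- compound 2 `O=C(Cn1ccnc1[N+](=O)[O-])N1CCN(c2ncccn2)CC1`: 280000 nM
- compound 3 `Cc1ccc(N2CCN(CC(=O)N3CCN(c4ccc(C)cc4)CC3)CC2)cc1`: 213000 nM

In an ADME assay on L6 cells (Rattus norvegicus) for cytotoxicity (a higher number here means a weaker inhibitor, a lower number a stronger inhibitor), compound 1 gives the lowest of the three numbers; compound 3 lies within the usual scatter of it, while compound 2 sits clearly higher. Compound 4 `O=C(Cn1cnc([N+](=O)[O-])n1)N1CCN(c2ncccn2)CC1` has not yet been measured. It differs from compound 1 in one place: pyrimidin-2-yl in place of 4-methoxyphenyl on an amine nitrogen in a ring. Among the measured compounds shown here, no measured pair shows this exact change, so the size of its effect is unknown. Compound 2, which also carries a pyrimidin-2-yl on the ring amine nitrogen, gives 280000 nM, and compound 4 is therefore expected to move toward a higher number, by a step of about a 1.8-fold higher number from compound 1 to compound 4 (0.26 log units; within the scatter). Compound 4 is estimated at 240000 nM, within a range from 110000 nM to 520000 nM.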

Compound 4, half-maximal inhibitory concentration: 150000 nM
Estimate against measurement, compound 4: 1.6-fold (0.20 log units) above; the range from low to high includes it.
By their numbers in this assay, from the lowest: compounds 1, 4, 3 and 2 (each within the scatter of the next, the first and the last beyond it).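

In this assay putting pyrimidin-2-yl in place of 4-methoxyphenyl on the ring amine nitrogen gives a 1.1-fold higher number from compound 1 to compound 4 (0.05 log units; within the scatter) and thus leaves the two numbers indistinguishable. On the core of compound 1, then, a ring of carbon only and a ring with two nitrogens read alike at this position. Nothing measured here offers an explanation for this.

Going by these compounds, whether this holds on other cores remains open, as a single pair cannot show it. Also open, on these data alone, is how a saturated group such as cyclohexyl, or a benzyl group, would read on that nitrogen.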